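The source may report more compounds than this note shows. Statements on the series, on what has been measured and on what is new or still open speak of the compounds shown alone.

Measured so far: compound 1 `CCOC(=O)CN1CCC[C@H](Nc2ncnc3ccc(-c4cnc(OC)c(C#N)c4)cc23)C1` with 500 nM, and compound 2 `COc1ncc(-c2ccc3ncnc(N[C@H]4CCCN(C(=O)C(F)(F)F)C4)c3c2)cc1[N+](=O)[O-]` with 127000 nM.

In a functional assay on SU-DHL-6 cells (Homo sapiens) for antiproliferative activity, read by MTT assay (on this read-out higher numbers stand for weaker inhibition and lower numbers for stronger inhibition), compound 1 gives 500 nM, the lowest of the two numbers. Compound 2 differs from compound 1 in several places. In this assay compound 2 gives 127000 nM, a far higher number and a gap well beyond the scatter. Going by the values given here, no single step connects these two compounds, so the two values show only that compound 1 is the stronger of the pair.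

Compound 3 `COc1ncc(-c2ccc3ncnc(N[C@H]4CCCN(C(=O)CCl)C4)c3c2)cc1C#N` has not yet been measured in this assay. It differs from compound 1 in one place: (chloromethyl)carbonyl in place of (ethoxycarbonyl)methyl on an amine nitrogen in a ring. Among the compounds with values here, no measured pair with this change exists, so the size of the step is open. The expectation rests on compound 1 and its value of 500 nM, with a step of a 2.0-fold lower number from compound 1 to compound 3 (0.30 log units; within the scatter) from compound 1 to compound 3, within or close to the scatter. Compound 3 is therefore estimated at 250 nM, in a range from 40 nM to 1500 nM.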

Compound 3, half-maximal inhibitory concentration: 380 nM
Compound 3: the middle estimate sits 1.5-fold (0.18 log units) below what was measured; measured number inside the range.
By their numbers in this assay, from the lowest: compounds 3 and 1 (each within the scatter of the next); then compound 2.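

In this assay, going by these compounds alone, (chloromethyl)carbonyl in place of (ethoxycarbonyl)methyl on the amine nitrogen in the ring gives a 1.3-fold lower number from compound 1 to compound 3 (0.12 log units; within the scatter) and thus provides the first single-place step at this position, one that stays within the scatter. The exchange replaces a group of 6 heavy atoms with one of 4 and brings in a chlorine, yet the values of compound 1 and compound 3 cannot be told apart on this read-out. No measurement on hand explains the size of this step.

Going by these compounds, what a free amine, a plain acetyl group or a carboxylic acid in place of the ethyl ester would give on this nitrogen remains open. On these data alone, whether the chlorine of compound 3 contributes to its value also remains open.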